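From dimethylamino to methyl: what compound 3 might do

A few compounds are considered here, and "the series" means these few. Any claim that something is new, unique, unknown or untested is made for them only; others in the source may bear on it.

In a functional assay on HeLa S3 cells (Homo sapiens) for antiproliferative activity, read by XTT assay, with a stated time of 72 h (a lower number here means a stronger inhibitor, a higher number a weaker inhibitor), compound 1, `CN(C)c1ncnc2c1c(-c1ccsc1)cn2[C@@H]1O[C@H](CO)[C@@H](O)[C@H]1O`, gives > 15000 nM, which is a limit and not a number. Compound 2, `CN(C)c1ncnc2c1c(-c1cc3ccccc3o1)cn2[C@@H]1O[C@H](CO)[C@@H](O)[C@H]1O`, gives > 20000 nM, also a limit. Compound 3, `Cc1ncnc2c1c(-c1ccsc1)cn2[C@@H]1O[C@H](CO)[C@@H](O)[C@H]1O`, has methyl in place of dimethylamino on an aromatic carbon. Within the data shown here, the only measured step is a step that the two limits leave unreadable from compound 1 to compound 2. It keeps dimethylamino and swaps a different group, so it offers no size to carry over. A step toward stronger inhibition is expected, estimated as an at least 10-fold lower number from compound 1 to compound 3 (1.00 log units; beyond the scatter), resting on the structural change alone. For compound 3 the estimate is 1500 nM, with an expected range from 150 nM to 15000 nM.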

Compound 3, half-maximal inhibitory concentration: 14300 nM
For compound 3 the middle estimate is 9.5-fold (0.98 log units) below the measured one; the measured number falls inside the stated range.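

In this assay compound 3 gives 14300 nM, the first result here that is a number and not a limit. Methyl in place of dimethylamino, next to the ring nitrogen, reads as an at least 1.0-fold lower number from compound 1 to compound 3 (0.02 log units; that floor lies within the scatter), so any gain beyond the scatter is neither shown nor excluded. Only this floor can be read because compound 1 carries a limit: the limit of > 15000 nM in this assay, at which 1 of the 3 values shown sits.

The compounds shown leave open how an ethyl chain or a primary amine would read at this place. They also leave open whether methyl gives a readable number alongside 1-benzofuran-2-yl.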